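Pentyl to Methylphenyl on an Amide Without Cytotoxicity

The compounds below may be only part of what the source reports. "The series", "measured", "known", "first", "only" and "open" are said of these compounds alone.

Of the compounds shown here, three of one shared core have been tested in an ADME assay on HepG2 2.2.15 cells (Homo sapiens) for cytotoxicity; a lower number here means that less compound is tolerated, a higher number that more compound is tolerated. Compound 1 `CCCCC(CC)CNc1ncc(C(Oc2ccc3cc(Br)ccc3c2)c2ccc(Cl)cc2)s1` is reported as "not toxic" (no number reported) and compound 2 `Clc1ccc(C(Oc2ccc3cc(Br)ccc3c2)c2cnc(NCC3CCOCC3)s2)cc1` as "not toxic" (no number reported), in both cases without a number. For compound 3 `CCCCCC(=O)Nc1ncc(C(Oc2ccc3cc(Br)ccc3c2)c2ccc(Cl)cc2)s1` only a limit of the assay is known, > 50000 nM, so compound 3 stands at the limit of > 50000 nM in this assay, at which 1 of the 3 values shown sits, rather than at a measured point. Compound 4 `Cc1ccc(C(=O)Nc2ncc(C(Oc3ccc4cc(Br)ccc4c3)c3ccc(Cl)cc3)s2)cc1` has not yet been measured; it differs from compound 3 by 4-methylphenyl in place of pentyl on a carbonyl carbon. Among the measured compounds shown here, with no measured step to draw on and all three known results showing no toxicity, the step that the limit leaves unreadable from compound 3 to compound 4 is expected to be none beyond the scatter. Compound 4 is therefore estimated at 60000 nM, between 25000 nM and 200000 nM, and most likely again reported only as a limit.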

Compound 4, half-maximal cytotoxic concentration: "not toxic" (no number reported)
Compound 4: no number reported, and the estimate cannot be compared.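

Among the compounds shown here, neither compound 3 nor compound 4 carries a measured number in this assay, so no step between them can be read. The compounds shown leave open at what concentration, if any, each would become cytotoxic.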